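The source may hold more compounds than are shown below. What is called first, only, known or untested is meant among the compounds shown, and "the series" means these compounds.

In a functional assay on A549 cells (Homo sapiens) for inhibition, read by MTT assay, with a stated time of 72 h (on this read-out higher numbers stand for weaker inhibition and lower numbers for stronger inhibition), compound 3 `COc1ccc(/C=C/C(=O)c2c(O)cc(O)cc2OC)cc1` gives > 50000 nM, which is a limit and not a number. Compound 1 `COc1ccc(/C=C/C(=O)c2c(OC)cc(O)c(CC=C(C)C)c2O)cc1` gives 38000 nM, and compound 2 `COc1cc(O)c(CC=C(C)C)c(O)c1C(=O)/C=C/c1ccc(C(F)(F)F)cc1` gives 11100 nM. Compound 4 `COc1cc(O)cc(O)c1C(=O)/C=C/c1ccc(C)cc1` has methyl in place of methoxy on an aromatic carbon, para to a large group, compared with compound 3 (methyl in place of methoxy on an aromatic carbon). Among the compounds with values here, two measured steps bear on this: a 3.4-fold lower number from compound 1 to compound 2 (0.53 log units; beyond the scatter), with trifluoromethyl in place of methoxy, and an at least 1.3-fold higher number from compound 1 to compound 3 (0.11 log units; that floor lies within the scatter), with hydrogen in place of 3-methylbut-2-en-1-yl. Neither is the same change, so in this assay a step smaller than the modest first one is expected, toward lower numbers, perhaps none beyond the scatter: an at least 1.1-fold lower number from compound 3 to compound 4 (0.04 log units; that floor lies within the scatter). Compound 4 is estimated at 45000 nM, within a range of 20000 nM to 90000 nM.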

Compound 4, half-maximal inhibitory concentration: > 50000 nM
Compound 4 gave a limit, no number; the forecaster's own chance of this, stated with the estimate: 60%; middle value at least 1.1-fold (0.04 log units) away from the limit.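

Within the data shown here, no step from compound 3 to compound 4 can be read, since each gives only a limit: the limit of > 50000 nM in this assay, at which 2 of the 4 values shown sit. The compounds shown leave open whether methyl in place of methoxy on an aromatic carbon changes inhibition at all.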